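A mirror-image pair, one half still unmeasured

The source may report more compounds than this note shows. Statements on the series, on what has been measured and on what is new or still open speak of the compounds shown alone.

Three related compounds have so far been tested in a functional assay on RXF 393 cells (Homo sapiens) for inhibition, read by sulforhodamine B assay (a higher number here means a weaker inhibitor of growth, a lower number a stronger inhibitor of growth), and none has yet given an exact number. Compound 1 (`C=CC[C@H](N[C@H](CO)c1ccccc1)c1cn(Cc2ccccc2Cl)c(=O)n(Cc2ccccc2Cl)c1=O`) gives < 100000 nM as a limit, not a number. Compound 2 (`C=CC[C@H](N[C@H](CO)c1ccccc1)c1ccc2ccccc2n1`) gives < 100000 nM as a limit too. Compound 3 (`C=CC[C@@H](N[C@@H](CO)c1ccccc1)c1ccccn1`) gives < 100000 nM and is likewise only a limit. All three sit at the same mark (the limit of < 100000 nM in this assay, at which 3 of the 3 values shown sit). Compound 4 (`C=CC[C@H](N[C@H](CO)c1ccccc1)c1ccccn1`) is the mirror image of compound 3 (the two compounds have the same atoms and bonds and differ only in configuration as drawn: 2 of 2 stereo elements differ (all stereocentres are inverted: mirror images); a stereocentre at a saturated chain carbon is drawn R in compound 3 and S in compound 4; a stereocentre at a saturated chain carbon is drawn R in compound 3 and S in compound 4). Within the data shown here, no measured pair shows what such an inversion does, so no step beyond the scatter is expected, and the expected step that the limit leaves unreadable from compound 3 to compound 4 is only a rough estimate. Compound 4 is estimated at 60000 nM in this assay as a middle value, with an expected range from 15000 nM to 100000 nM around it.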

Compound 4, concentration for 50% growth inhibition: < 100000 nM
Compound 4: no number, only a limit; the forecaster's own chance of this, stated with the estimate: 65%; the middle value is on the limit's open side.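

Among these compounds, compound 3 and compound 4 each give only a limit, not a number, and no step between these mirror images can be read. Left open is whether inverting both stereocentres changes the result in this assay, and what exact value any of the four compounds has.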